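The compounds below may be only part of what the source reports. "The series", "measured", "known", "first", "only" and "open" are said of these compounds alone.

Compound 1 `Cc1c(C(=O)N[C@@H]2CCCC[C@H]2O)cc(-c2cc(C(F)(F)F)ccc2Cl)n1CC1CCCCC1`: 1.32 mL/min/kg
Compound 2 `O=C(N[C@@H]1CCCC[C@H]1O)c1cnc(OCc2ccccc2)c(-c2ccc(Cl)cc2)c1`: 0.02 mL/min/kg

Both compounds were tested in an ADME assay (liver) for pharmacokinetics, with Liver microsome (Rattus norvegicus) as the target, read by LC-MS, using microsomes, tested at 2 uM; a higher number here means faster removal of the compound, a lower number slower removal. In this assay compound 2 gives 0.02 mL/min/kg, the lowest of the two numbers seen, while compound 1 gives 1.32 mL/min/kg, a far higher number that lies well beyond the usual scatter. Within the data shown here, the two compounds differ in many places at once, so no single structural step between them can be read out of these values.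

Compound 3 `CN(CC1CC1)c1ncc(C(=O)N[C@@H]2CCCC[C@H]2O)cc1-c1ccc(Cl)cc1` has not yet been measured. It differs from compound 2 in one place: (cyclopropylmethyl)(methyl)amino in place of benzyloxy on an aromatic carbon. Among the measured compounds shown here, no measured pair shows this change, so the direction of the step is uncertain. Because compound 2 sits at 0.02 mL/min/kg, a very low number, the step from it is expected to be modest and upward: a 5.0-fold higher number from compound 2 to compound 3 (0.70 log units; beyond the scatter). Compound 3 is therefore estimated at 0.1 mL/min/kg, in a range from 0.02 mL/min/kg to 0.6 mL/min/kg.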

Compound 3, clearance: 1.73 mL/min/kg
For compound 3 the middle estimate is 17-fold (1.24 log units) below the measured one, outside the stated range (above it).
By their numbers in this assay, from the lowest: compound 2; then compounds 1 and 3 (each within the scatter of the next).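

In this assay, replacing benzyloxy with (cyclopropylmethyl)(methyl)amino on the aromatic carbon next to the ring nitrogen gives an 87-fold higher number from compound 2 to compound 3 (1.94 log units; beyond the scatter), so this one position can strongly change the read-out. Among these compounds, this is the first comparison in which everything else in the molecule stays the same, which the earlier pair, differing in many places, could not offer. No measurement at hand gives a reason for the size of this step.

The change swaps the oxygen attached to the ring for a nitrogen and also replaces the group beyond that atom, so these two parts of the change remain tangled. From the compounds shown here alone, a benzylamino group, which keeps the benzyl part, or a cyclopropylmethoxy group, which keeps the oxygen, could show which part matters, and whether either would land near compound 2 or near compound 3 remains open.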